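Amide swap on the ring amine: clearance notes

This account rests on a few compounds, and the source may have more. Where it says the series, first, only, none or still open, it means among the compounds named here.

Measured so far:
- Compound 1 `CC(C)n1cc(-c2ccnc3[nH]c(C4CCNCC4)cc23)ccc1=O` gives < 3 uL/min in an ADME assay on microsomes from liver (Homo sapiens) for metabolic stability (a higher number here means faster removal of the compound, a lower number slower removal), a limit of the assay.
- Compound 2 `CC(=O)N1CCC(c2cc3c(-c4ccc(=O)n(C(C)C)c4)ccnc3[nH]2)CC1` gives < 3 uL/min in this assay, also a limit.
- Compound 3 `CN(C)C(=O)CN1CCC(c2cc3c(-c4ccc(=O)n(CCC5CCOCC5)c4)ccnc3[nH]2)CC1` gives 19 uL/min in this assay.

Compound 2 stands at the limit of < 3 uL/min in this assay, at which 2 of the 3 values shown sit, so only a limit is known for it. Going by the values given here, the one step that reaches it, a step that the two limits leave unreadable from compound 1 to compound 2, is acetyl in place of hydrogen on an amine nitrogen in a ring, and both ends being limits it cannot be sized. Among the compounds with values here, compound 3 differs from compound 2 in more than one place, so its value shows only that a numeric reading is reached.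

Compound 4 `CC(C)n1cc(-c2ccnc3[nH]c(C4CCN(CC(=O)N5CCCCC5)CC4)cc23)ccc1=O` differs from compound 2 by ((piperidin-1-yl)carbonyl)methyl in place of acetyl on an amine nitrogen in a ring. Within the data shown here, no measured step covers this change, and the single step touching compound 2 is unreadable, so no direction can be read from the measured pairs. As a working guess compound 4 is expected to move by an at least 2.6-fold higher number from compound 2 to compound 4 (0.42 log units; beyond the scatter), a shift that may exceed the scatter only loosely given the limit at compound 2. Compound 4 is therefore estimated at 8 uL/min in this assay, within 3 uL/min to 25 uL/min.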

Compound 4, intrinsic clearance in a liver preparation (reported as CLH), per the amount of preparation that the assay uses: > 300 uL/min
Compound 4 was reported as a limit; the forecaster's own chance of this, stated with the estimate: 30%; middle value at least 37-fold (1.57 log units) from the limit.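

In this assay, replacing acetyl with ((piperidin-1-yl)carbonyl)methyl on the amine nitrogen in the ring gives an at least 100-fold higher number from compound 2 to compound 4 (2.00 log units; beyond the scatter), and replacing hydrogen with the same group gives an at least 100-fold higher number from compound 1 to compound 4 (2.00 log units; beyond the scatter). Going by these compounds alone, these are the first readable steps at this position, and both are large and beyond the scatter, whereas the step from hydrogen to acetyl cannot be read. Compound 4 gives > 300 uL/min, which is a limit of the assay.

On these data alone, it remains open whether the step belongs to the six-membered non-aromatic ring of the entering group or needs the whole group, a question that a (morpholin-4-yl)carbonylmethyl group or a carboxylic acid on this nitrogen would help to separate. Compound 3 differs from compound 4 in more than one place and cannot settle this.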